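Changing the aryloxy group of compound 2 toward a methoxyphenyl ether

The source may hold more compounds than are shown below. What is called first, only, known or untested is meant among the compounds shown, and "the series" means these compounds.

Measured so far:
Compound 1 `COc1ccc(C(c2ccc(OC)cc2)N2CCN(C(=O)COc3ccc4ccccc4c3)CC2)cc1`: 25.6%
Compound 2 `COc1ccc(C(c2ccc(OC)cc2)N2CCN(C(=O)COc3ccccc3C)CC2)cc1`: 21.2%
Compound 3 `COc1ccc(OCC(=O)N2CCN(C(c3ccc(F)cc3)c3ccc(F)cc3)CC2)cc1`: 80.5%

The read-out is a functional assay on PC-12 cells (Rattus norvegicus) for cytotoxicity, read by MTT assay, with a stated time of 24 h, tested at 10 uM; on this read-out higher numbers stand for a stronger effect at the one concentration tested and lower numbers for a weaker effect. Among the three measured numbers, compound 2 gives the lowest one. Its nearest neighbour is compound 1, whose number lies within the scatter of that of compound 2, so these two cannot be told apart. Compound 3 stands far away with a much higher number.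

The compound now in question is compound 4 `COc1ccc(OCC(=O)N2CCN(C(c3ccc(OC)cc3)c3ccc(OC)cc3)CC2)cc1`. The change from compound 2 is 4-methoxyphenyl in place of 2-methylphenyl on an oxygen on a saturated carbon.

For the measured compounds named here, only one measured step touches the same place, the ether on the saturated carbon: a number 4.4 percentage points lower from compound 1 to compound 2 (within the scatter), which lies within the scatter and therefore gives no direction. Compound 3 carries the same 4-methoxyphenoxy group as compound 4, but differs from compound 2 at a second place too, so its high number only hints that this ether is compatible with a strong effect.

On this basis compound 4 is expected to give 40%, within 15% to 75%, meaning an expected step of a number 18.8 percentage points higher from compound 2 to compound 4 (beyond the scatter).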

Compound 4, a percentage reported as activity, at one concentration (the size of the read-out at that concentration, not a potency): 56.7%
Compound 4: middle estimate off by 16.7 percentage points, on the low side; low and high end bracket the measured number.
By their numbers in this assay, from the lowest: compounds 2 and 1 (each within the scatter of the next); then compound 4; then compound 3.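

In this assay the group on the oxygen on a saturated carbon now proves able to shift the read-out, which the earlier step within the scatter could not show. Replacing 2-methylphenyl with 4-methoxyphenyl gives a number 35.5 percentage points higher from compound 2 to compound 4 (beyond the scatter) and replacing naphthalen-2-yl with 4-methoxyphenyl gives a number 31.1 percentage points higher from compound 1 to compound 4 (beyond the scatter) in the same direction, so compound 4 stands clearly apart from both. No measurement is available here that explains these steps.

Still open, going by these compounds, is whether the steps follow the methoxy group itself or the place it occupies on the ring, and a 2-methoxyphenyl or a 4-methylphenyl group at this position would separate the two. Also open, on these data alone, is how an amine or a carboxylic acid on this ring would read in this assay at this position.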